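Closing the Benzyl(methyl)amino of Compound 1 into a Ring

The source may hold more compounds than are shown below. What is called first, only, known or untested is meant among the compounds shown, and "the series" means these compounds.

Compound 1 `COc1cc2c(Nc3ccc(C#N)cc3)ncnc2cc1OCCCN(C)Cc1ccccc1` is one of three close relatives built on a shared core and tested for antiproliferative activity in a functional assay on DU-145 cells (Homo sapiens) for antiproliferative activity, read by MTT assay, with a stated time of 72 h; a higher number here means a weaker inhibitor, a lower number a stronger inhibitor. In this assay compound 1 gives only a limit, > 100000 nM, so its standing is known as a bound rather than a number. Compound 2 `COc1cc2c(Nc3ccc(C#N)cc3)ncnc2cc1OCCCN1CCC(CO)CC1` gives 53200 nM in this assay. Compound 3 `COc1cc2c(Nc3ccc(C#N)cc3)ncnc2cc1OCCCN1CCCCC1CCO` again reaches only the limit of this assay, > 100000 nM. The step from compound 1 to compound 2 is an at least 1.8-fold lower number from compound 1 to compound 2 (0.27 log units; that floor lies within the scatter), and the step from compound 1 to compound 3 is a step that the two limits leave unreadable from compound 1 to compound 3; the limit of > 100000 nM in this assay, at which 2 of the 3 values shown sit, keeps both of these steps poorly defined.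

Compound 4 `COc1cc2c(Nc3ccc(C#N)cc3)ncnc2cc1OCCCN1CCc2ccccc2C1` differs from compound 1 by 1,2,3,4-tetrahydroisoquinolin-2-yl in place of benzyl(methyl)amino on a saturated chain carbon, three bonds along the chain from an oxygen on an aromatic ring. The two measured steps from compound 1 both exchange the benzyl(methyl)amino for 4-(hydroxymethyl)piperidin-1-yl or 2-(2-hydroxyethyl)piperidin-1-yl, which is not the exchange made here, and neither step showed a readable size beyond the scatter. Nothing in these numbers points to a large move in either direction, so compound 4 is expected to remain in the same weak region as compound 1, with an estimated step of a number no higher from compound 1 to compound 4 (the limit leaves the size open). For compound 4 the estimate in this assay is 100000 nM, expected to fall between 30000 nM and 300000 nM.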

Compound 4, half-maximal inhibitory concentration: > 100000 nM
Compound 4: only a limit was reported; the forecaster's own chance of this, stated with the estimate: 60%; the middle value lies on the limit itself.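

With compound 4, the benzyl(methyl)amino on this saturated chain carbon has been closed into 1,2,3,4-tetrahydroisoquinolin-2-yl, and in this assay the result is again only a limit, so this ring closure yields no measurable number. Going by these compounds alone, the one step that can be read is an at least 1.8-fold higher number from compound 2 to compound 4 (0.27 log units; that floor lies within the scatter); compound 2 remains the only one of the four compounds with a number, but this step does not separate it from compound 4 beyond the scatter. The steps from compound 1 and from compound 3 to compound 4 cannot be read, because each has a limit at both ends: the limit of > 100000 nM in this assay, at which 3 of the 4 values shown sit.

Going by these compounds, how far compound 1, compound 3 and compound 4 lie from one another beyond that limit remains open, so the exchange of benzyl(methyl)amino for 1,2,3,4-tetrahydroisoquinolin-2-yl has no readable size. Also open, on these data alone, is whether a morpholin-4-yl or a dimethylamino group at this same place, three bonds along the chain from an oxygen on an aromatic ring, would give a number rather than a limit.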